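Aminophenyl in place of nitrophenyl: expecting a lower number

The compounds below may be only part of what the source reports. "The series", "measured", "known", "first", "only" and "open" are said of these compounds alone.

Measured compounds:
compound 1 `CCOC(=O)C1=C(C)NC(=S)NC1c1cn(C(=O)CNc2ccc([N+](=O)[O-])cc2C)c2ccccc12`: 48 ug/mL
compound 2 `CCOC(=O)C1=C(C)NC(=O)NC1c1cn(C(=O)CNc2ccc([N+](=O)[O-])cc2)c2ccccc12`: > 1000 ug/mL, a limit of the assay and not a number
compound 3 `CCOC(=O)C1=C(C)NC(=O)NC1c1cn(C(=O)CNc2ccccc2N)c2ccccc12`: 2.5 ug/mL

In a functional assay on MCF7 cells (Homo sapiens) for cytotoxicity, read by MTT assay, with a stated time of 72 h (on this read-out lower numbers stand for stronger inhibition and higher numbers for weaker inhibition), compound 1 gives 48 ug/mL, the highest of the two real numbers shown. Compound 3 gives 2.5 ug/mL, lower than compound 1 by a step beyond the scatter. Compound 2 gives only > 1000 ug/mL, which is a limit of the assay.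

Compound 4 `CCOC(=O)C1=C(C)NC(=S)NC1c1cn(C(=O)CNc2ccccc2N)c2ccccc12` differs from compound 1 by 2-aminophenyl in place of 2-methyl-4-nitrophenyl on an amine nitrogen. Among the measured compounds shown here, the one measured step that bears on this change is an at least 400-fold lower number from compound 2 to compound 3 (2.60 log units; beyond the scatter), which likewise puts a 2-aminophenyl where a nitro-bearing phenyl stood on the amine nitrogen. Because compound 2 sits at the limit of > 1000 ug/mL in this assay, at which 1 of the 3 values shown sits, that step is known only as a lower bound, and the shared core of compounds 2 and 3 is not the same as that of compound 1, whose starting number is already far from that limit. A lower number for compound 4 is therefore expected in this assay, with a step of a 9.6-fold lower number from compound 1 to compound 4 (0.98 log units; beyond the scatter) estimated. Compound 4 is expected at about 5 ug/mL, between 1 ug/mL and 30 ug/mL.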

Compound 4, half-maximal inhibitory concentration: 100 ug/mL
Compound 4: the middle estimate sits 20-fold (1.30 log units) below what was measured; measured number outside the range, above it.
By their numbers in this assay, from the lowest: compound 3; then compound 1; then compound 4. At a limit, above all of these: compound 2.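

In this assay, the same kind of change runs the opposite way on the core of compound 1, with a 2.1-fold higher number from compound 1 to compound 4 (0.32 log units; beyond the scatter), a modest step, set against an at least 400-fold lower number from compound 2 to compound 3 (2.60 log units; beyond the scatter) on the other core. The large drop seen with a 2-aminophenyl on the amine nitrogen therefore does not carry over to the core of compound 1, and this group does not give a low number whatever core it sits on. That earlier step also rests on compound 2, whose value is a limit and not a number: the limit of > 1000 ug/mL in this assay, at which 1 of the 4 values shown sits.

The change takes away a methyl and a nitro group and brings in an amine in a single move, so the compounds shown cannot tell which of these counts. Also open, from the compounds shown here alone, is how a phenyl carrying a methoxy group or a carboxylic acid on this amine nitrogen would read in this assay.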